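Ester to acid on the thioether side chain

This account rests on a few compounds, and the source may have more. Where it says the series, first, only, none or still open, it means among the compounds named here.

Working notes on a small set of pyrimidine-type thioethers tested in an assay for inhibition of Polyunsaturated fatty acid 5-lipoxygenase (Homo sapiens), tested at 1 uM; on this read-out lower numbers stand for a stronger effect and higher numbers for a weaker effect at the one concentration tested. Compound 1 `CCOC(=O)C(C)Sc1nc(Cl)cc(Nc2ccc3ncccc3c2)n1` gives "not active" (no number reported) in this assay. Compound 2 `CCCCCCC(Sc1nc(Cl)cc(Nc2cccc(C)c2C)n1)C(=O)OCC` gives 84.9% in this assay, a weak effect at the one concentration tested. Within the data shown here, compound 3 `CCOC(=O)C(C)Sc1nc(Cl)cc(Nc2cccc(C)c2C)n1` gives "not active" (no number reported) in this assay, so no number stands for it; it sits with compound 1 among the entries without a reported value, while compound 2 is the only member with a measured read-out.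

The next member is compound 4 `Cc1cccc(Nc2cc(Cl)nc(SC(C)C(=O)O)n2)c1C`, which differs from compound 3 by hydrogen in place of ethyl on an oxygen next to a carbonyl group. The change is small in atom count and alters nothing elsewhere in the structure. Among the measured compounds shown here, no measured step of this kind exists in the set, so there is no basis for expecting a change beyond the scatter in either direction; the likeliest outcome is that compound 4 again shows little or no effect in this assay, and a report of "not active" without a number is a real possibility. Compound 4 is therefore estimated at 88%, expected to lie between 60% and 105% should a number be reported.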

Compound 4, a percentage reported as activity, at one concentration (the size of the read-out at that concentration, not a potency): "not active" (no number reported)
The entry for compound 4 holds no number; there is nothing to compare the estimate with.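

In this assay compound 3 gives "not active" (no number reported) and compound 4 gives "not active" (no number reported), so no step can be read for this pair. The compounds shown leave open what ethoxycarbonyl to carboxy does where a number is reported. No evidence bears on this result.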